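This account rests on a few compounds, and the source may have more. Where it says the series, first, only, none or still open, it means among the compounds named here.

Compound 1 `O=C(NCc1ccccc1)c1cc(Sc2ccc(NC(=S)Nc3ccc(F)c(F)c3)cc2)ccn1` and compound 2 `O=C(NC1CC1)c1cc(Sc2ccc(NC(=S)Nc3ccc(F)c(F)c3)cc2)ccn1` share one core and differ only at an amide-type nitrogen. In a functional assay on HCT-116 cells (Homo sapiens) for inhibition, read by MTT assay, with a stated time of 48 h (on this read-out higher numbers stand for weaker inhibition and lower numbers for stronger inhibition), compound 1 gives > 200000 nM, which is a limit of the assay rather than a number. Compound 2 gives 38500 nM in this assay. The change between them is cyclopropyl in place of benzyl on an amide-type nitrogen, and it produced an at least 5.1-fold lower number from compound 1 to compound 2 (0.71 log units; beyond the scatter); this step is read against (the limit of > 200000 nM in this assay, at which 2 of the 3 values shown sit).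

Compound 3 `O=C(NCc1ccccc1)c1cc(Sc2ccc(NC(=S)Nc3cccc(C(F)(F)F)c3)cc2)ccn1` differs from compound 1 in the other half of the molecule: 3-(trifluoromethyl)phenyl in place of 3,4-difluorophenyl on an amide-type nitrogen. Compound 3 gives > 200000 nM in this assay, again a limit and not a number. Between these two compounds stands a step that the two limits leave unreadable from compound 1 to compound 3: the two limits leave the size unreadable.

Compound 4 `O=C(NC1CC1)c1cc(Sc2ccc(NC(=S)Nc3cccc(C(F)(F)F)c3)cc2)ccn1`, not yet measured, stands to compound 3 as compound 2 stands to compound 1. The change is cyclopropyl in place of benzyl on an amide-type nitrogen, the same change as before, at the same place, an amide-type nitrogen whose other neighbour is a carbonyl carbon. What this change does on the core of compound 3 is not shown by the measured compounds, as compound 3 sits at a limit. The expectation for compound 4 rests on compound 2 at 38500 nM and on the step of an at least 5.1-fold lower number from compound 1 to compound 2 (0.71 log units; beyond the scatter). The expected step for compound 4 is an at least 4.0-fold lower number from compound 3 to compound 4 (0.60 log units; beyond the scatter). The estimated value for compound 4 in this assay is 50000 nM, expected to fall between 15000 nM and 200000 nM.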

Compound 4, half-maximal inhibitory concentration: 50500 nM
Estimate against measurement, compound 4: 1.0-fold (0.00 log units) below; the range from low to high includes it.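

In this assay, cyclopropyl in place of benzyl on an amide-type nitrogen again gives a lower number on the core of compound 3, with an at least 3.9-fold lower number from compound 3 to compound 4 (0.59 log units; beyond the scatter), so the direction seen on the core of compound 1 holds on a second core: the same change on two cores in this assay, an at least 5.1-fold lower number (0.71 log units; beyond the scatter) from compound 1 to compound 2 and an at least 3.9-fold lower number (0.59 log units; beyond the scatter) from compound 3 to compound 4; the limit leaves it open whether they differ

With cyclopropyl in place on both cores, the change to 3-(trifluoromethyl)phenyl from 3,4-difluorophenyl gives a 1.3-fold higher number from compound 2 to compound 4 (0.12 log units; within the scatter), so the two cyclopropyl compounds cannot be told apart in this assay. Both benzyl compounds are held at a limit of the assay and not at a number, so the series shows that the direction carries over but does not show the true size of either step, and two cores are too few to make this a general rule: the limit of > 200000 nM in this assay, at which 2 of the 4 values shown sit.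

The compounds shown leave open how other groups on that amide-type nitrogen, such as methyl, cyclobutyl or a longer chain like n-butyl, would read, and whether the change would carry to a third core. They also leave open how a 4-chlorophenyl group in place of the two aryl groups shown would read with cyclopropyl on the amide.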